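This account rests on a few compounds, and the source may have more. Where it says the series, first, only, none or still open, it means among the compounds named here.

The measured compounds:

Compound 1, `Cc1cc(-c2c(F)cc3c(=O)ccn(C4CC4)c3c2F)cc(C)n1`: in a functional assay on P388 cells (Mus musculus) for cytotoxicity (a higher number here means a weaker inhibitor, a lower number a stronger inhibitor), compound 1 gives 15000 nM.
Compound 2, `COc1ccccc1Cc1cn(C2CC2)c2c(F)c(-c3cc(C)nc(C)c3)c(F)cc2c1=O`: in this assay compound 2 gives 37000 nM.
Compound 3, `Cc1cc(-c2c(F)cc3c(=O)c(Cc4ccc(Cl)cc4)cn(C4CC4)c3c2F)cc(C)n1`: in this assay compound 3 gives 20000 nM.

Compound 2 holds the highest of the three numbers in this assay. Its gap to compound 3 is within the scatter, a 1.9-fold lower number from compound 2 to compound 3 (0.27 log units; within the scatter), while its gap to compound 1 lies beyond it, a 2.5-fold higher number from compound 1 to compound 2 (0.39 log units; beyond the scatter).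

Compound 4, `Cc1cc(-c2c(F)cc3c(=O)c(Cc4ccccc4O)cn(C4CC4)c3c2F)cc(C)n1`, has not yet been measured. It differs from compound 2 in a single place: hydrogen in place of methyl on an oxygen on an aromatic ring. For the measured compounds named here, no measured step removes a methyl from an oxygen on an aromatic ring, so nothing bears directly on this change. The steps that touch the same part of the shared core are those that introduce a benzyl group, a 2.5-fold higher number from compound 1 to compound 2 (0.39 log units; beyond the scatter) and a 1.3-fold higher number from compound 1 to compound 3 (0.12 log units; within the scatter), and the exchange of one benzyl group for another, a 1.9-fold lower number from compound 2 to compound 3 (0.27 log units; within the scatter). Together they show that the whole benzyl group moves the number only modestly, and that changing its substituent shifts it within the scatter. A change from methoxy to hydroxy is smaller than either of those, so no step beyond the scatter is expected in this assay, in either direction.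

Compound 4 is therefore estimated at 30000 nM, with a range from 12000 nM to 75000 nM. The expected step is a 1.2-fold lower number from compound 2 to compound 4 (0.09 log units; within the scatter).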

Compound 4, half-maximal inhibitory concentration: 670 nM
The estimate for compound 4 lay 45-fold (1.65 log units) above the measured number; measured number outside the range, below it.
By their numbers in this assay, from the lowest: compound 4; then compounds 1, 3 and 2 (each within the scatter of the next, the first and the last beyond it).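

In this assay, replacing the methyl on this oxygen with hydrogen gives a 55-fold lower number from compound 2 to compound 4 (1.74 log units; beyond the scatter), a far larger change than the earlier benzyl steps suggested, where adding 2-methoxybenzyl gave a 2.5-fold higher number from compound 1 to compound 2 (0.39 log units; beyond the scatter) and adding 4-chlorobenzyl gave a 1.3-fold higher number from compound 1 to compound 3 (0.12 log units; within the scatter). The 2-hydroxybenzyl group is thus the only one of the three benzyl groups to lower the number relative to the unsubstituted compound, with a 22-fold lower number from compound 1 to compound 4 (1.35 log units; beyond the scatter), so a benzyl group at this position does not by itself account for the result. The exchange of 4-chlorophenyl for 2-hydroxyphenyl, a 30-fold lower number from compound 3 to compound 4 (1.47 log units; beyond the scatter), points the same way and places the large drop with the hydroxy group of compound 4, the only compound shown that carries one.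

Going by these compounds, whether an amine or a carboxylic acid in place of this hydroxy would give a similarly low number remains open, as does whether the low number seen in this cytotoxicity read-out would carry over to any other assay. Nothing available here explains the size of this step.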